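Swapping an aromatic ring for a saturated one

The source may report more compounds than this note shows. Statements on the series, on what has been measured and on what is new or still open speak of the compounds shown alone.

Compound 1 `COc1cccc(NC2=CC(=O)c3nc4n(c3C2=O)[C@H]2OC[C@@H](O)[C@H]2OC4)c1`: in a functional assay on ECa-109 cells for inhibition, with ECa-109 cell line (Homo sapiens) as the target, read by sulforhodamine B assay (on this read-out higher numbers stand for weaker inhibition and lower numbers for stronger inhibition), compound 1 gives 7620 nM.
Compound 2 `CCOc1ccccc1NC1=CC(=O)c2c(nc3n2[C@H]2OC[C@@H](O)[C@H]2OC3)C1=O`: in this assay compound 2 gives 4320 nM.

Both measured compounds share the same core and differ only in the aromatic group carried on the amine nitrogen. Among the compounds with values here, compound 1 has the larger of the two numbers, but its gap to compound 2 lies within the usual scatter of repeated measurements, so the two cannot be said to differ in inhibition, and no step between them has been worked out.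

Compound 3 `O=C1C=C(NC2CCCCC2)C(=O)c2c1nc1n2[C@H]2OC[C@@H](O)[C@H]2OC1` keeps the core and carries the change (cyclohexyl in place of 3-methoxyphenyl on an amine nitrogen). An aromatic ring that bears a hydrogen-bond acceptor leaves, and a saturated ring with none takes its place on the amine nitrogen.

Nothing measured shows how a swap of this kind moves the numbers, so the expectation rests on compound 1 alone and is held loosely. Compound 3 is estimated at 6000 nM, with a likely range from 1500 nM to 25000 nM. That estimate means an expected step of a 1.3-fold lower number from compound 1 to compound 3 (0.10 log units; within the scatter), one that is not expected to reach beyond the scatter, although the range is wide.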

Compound 3, half-maximal inhibitory concentration: > 16000 nM
Compound 3: no number, only a limit; the forecaster's own chance of this, stated with the estimate: 10%; at least 2.6-fold (0.42 log units) between middle value and limit.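

In this assay compound 3 gives > 16000 nM, which is a limit of the assay and not a number. Even read from that limit, putting cyclohexyl in place of 3-methoxyphenyl on the amine nitrogen brings an at least 2.0-fold higher number from compound 1 to compound 3 (0.32 log units; beyond the scatter), and on this read-out that means weaker inhibition. Within the data shown here, compound 1 and compound 2 carry two different aromatic groups on this nitrogen and stay within the scatter of each other, so this is the first change here that shows up clearly in the numbers, and it shows that the group on this nitrogen is not a matter of indifference to the read-out.

The change in compound 3 removes the aromatic ring and the methoxy oxygen together, and the compounds shown cannot say which of the two losses matters. A plain phenyl on the same nitrogen would keep the aromatic ring without the methoxy oxygen, while a methoxy-bearing cyclohexyl would keep the oxygen on a saturated ring, and either would begin to pull the two apart.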